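One Added Chain Carbon on Compound 2

The source may report more compounds than this note shows. Statements on the series, on what has been measured and on what is new or still open speak of the compounds shown alone.

Compound 1 `CNC(=O)CCCCCCCn1nc(-c2cnc3[nH]ccc3c2)c2c(N)ncnc21`: 29100 nM
Compound 2 `Nc1nc2cc(-c3nn(CCCCCC(=O)NO)c4ncnc(N)c34)ccc2o1`: 15400 nM
Compound 3 `Nc1ncnc2c1c(-c1cnc3[nH]ccc3c1)nn2CCCC(=O)NO`: "not determined" (no result reported)

These results come from a functional assay on HeLa cells (Homo sapiens) for inhibition, read by MTT assay, with a stated time of 72 h (a lower number here means a stronger inhibitor, a higher number a weaker inhibitor), where the number for compound 2 lies within the usual scatter of the number for compound 1, and compound 3 has no number to set beside them. Compound 4 `Nc1nc2cc(-c3nn(CCCCCCC(=O)NO)c4ncnc(N)c34)ccc2o1` changes compound 2 in one place (hydroxycarbamoyl)methyl in place of hydroxycarbamoyl on a saturated chain carbon, five bonds along the chain from an aromatic nitrogen with (hydroxycarbamoyl)methyl in place of hydroxycarbamoyl on a saturated chain carbon, five bonds along the chain from an aromatic nitrogen. Among the compounds with values here, no measured pair shows such a change, so no shift beyond the scatter is expected in either direction. The estimated step of a 1.2-fold lower number from compound 2 to compound 4 (0.07 log units; within the scatter) is expected to be small. In this assay compound 4 is estimated at 13000 nM (range 5000 nM to 32000 nM).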

Compound 4, half-maximal inhibitory concentration: 6410 nM
Estimate against measurement, compound 4: 2.0-fold (0.31 log units) above; low and high end bracket the measured number.
By their numbers in this assay, from the lowest: compound 4; then compounds 2 and 1 (each within the scatter of the next).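

In this assay the change to (hydroxycarbamoyl)methyl from hydroxycarbamoyl on a saturated chain carbon, five bonds along the chain from an aromatic nitrogen, gives a 2.4-fold lower number from compound 2 to compound 4 (0.38 log units; beyond the scatter) and so a modest step beyond the scatter. Within the data shown here, the earlier compounds offered no pair differing in one place, so this is the first sign that a single added carbon at this place can move the number. No measurement shown here accounts for the step.

From the compounds shown here alone, whether a longer chain would lower the number further remains open, since one step cannot define a trend. Also open, going by these compounds, is how a carboxylic acid in place of hydroxycarbamoyl would compare.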